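A Tetrazole Gives Way to a Pyrazole

The compounds below may be only part of what the source reports. "The series", "measured", "known", "first", "only" and "open" are said of these compounds alone.

Three ureas sharing one core have been measured in an assay on microsomes from intestine for inhibition of acyl-CoA:cholesterol acyltransferase (Oryctolagus cuniculus); a higher number here means a weaker inhibitor, a lower number a stronger inhibitor. Compound 1 `Cc1cc(C)c(NC(=O)N(Cc2cc(-c3ccccc3)cs2)C2CCCCCC2)c(C)c1` gives 36 nM in this assay. Compound 2 `Cc1cc(C)c(NC(=O)N(Cc2ccc(-c3ccccc3)nc2)C2CCCCCC2)c(C)c1` gives 260 nM in this assay. Compound 3 `Cc1cc(C)c(NC(=O)N(Cc2cccc(-c3nnn(C)n3)c2)C2CCCCCC2)c(C)c1` gives 100 nM in this assay. Among these three numbers compound 3 holds the second highest; its nearest neighbour is compound 2, and the gap between them lies beyond the usual scatter, while compound 1 sits at a lower number, again by a gap beyond the scatter. Among the measured compounds shown here, none of the three pairs differs in only one place, so no single-point step is available from the measured set.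

Compound 4 `Cc1cc(C)c(NC(=O)N(Cc2cccc(-c3cnn(C)c3)c2)C2CCCCCC2)c(C)c1` is not yet measured. It differs from compound 3 in one respect: 1-methyl-1H-pyrazol-4-yl in place of 2-methyl-2H-tetrazol-5-yl on an aromatic carbon, that is, a 1-methyl-1H-pyrazol-4-yl in place of a 2-methyl-2H-tetrazol-5-yl on an aromatic carbon of the six-membered carbon ring, meta to a large group. Nothing in the measured compounds shows how an exchange of one five-membered ring for another at this spot moves the result. He therefore expects the step from compound 3 to compound 4 to be small, likely within the scatter, with no clear direction, as expressed by a 1.3-fold lower number from compound 3 to compound 4 (0.10 log units; within the scatter). For compound 4 in this assay he estimates 80 nM, expected to fall between 30 nM and 250 nM.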

Compound 4, half-maximal inhibitory concentration: 44 nM
For compound 4 the middle estimate is 1.8-fold (0.26 log units) above the measured one; low and high end bracket the measured number.
By their numbers in this assay, from the lowest: compounds 1 and 4 (each within the scatter of the next); then compound 3; then compound 2.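

In this assay, putting a 1-methyl-1H-pyrazol-4-yl in place of the 2-methyl-2H-tetrazol-5-yl gives a 2.3-fold lower number from compound 3 to compound 4 (0.36 log units; beyond the scatter). Among the compounds shown here, this is the first step that changes only one place, and it shows that the five-membered ring on this aromatic carbon is not a neutral part of the molecule: the number responds to the identity of that ring. The two rings match in heavy-atom count and in carrying no net charge, so the step comes from an exchange of ring nitrogen for ring carbon, although nothing available explains why the number moves.

A single exchange cannot show whether the number would keep falling with still fewer ring nitrogens, as with a plain phenyl ring on the same carbon, or whether the pyrazole is a special case among such rings. As far as these compounds go, the part played by the methyl group on the pyrazole also stays open, and a pyrazole carrying an ethyl group or only the ring hydrogen in its place would bear on that question.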